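Fluoro for dimethylamino on the fused ring of compound 2

This account rests on a few compounds, and the source may have more. Where it says the series, first, only, none or still open, it means among the compounds named here.

Compound 1 `CCCC[C@]1(CC)CS(=O)(=O)c2ccc(NC(C)=O)cc2[C@@H](c2ccccc2)[C@H]1O` and compound 2 `CCCCC1(CCCC)CS(=O)(=O)c2c(cccc2N(C)C)[C@@H](c2ccc(F)cc2)[C@H]1O` share a core and were both tested in an assay on cells for inhibition of ileal sodium/bile acid cotransporter (Homo sapiens); on this read-out higher numbers stand for weaker inhibition and lower numbers for stronger inhibition. Compound 1 gives 90 nM in this assay. Compound 2 gives 180 nM, and the two numbers lie within the usual scatter of each other, so nothing separates them. Compound 3 `CCCCC1(CCCC)CS(=O)(=O)c2c(F)cccc2[C@@H](c2ccc(F)cc2)[C@H]1O` has not yet been measured. It differs from compound 2 in one place: fluoro in place of dimethylamino on an aromatic carbon. Among the compounds with values here, no measured pair shows this exchange, so its effect on this assay is unknown. Without any comparable step in the data, the expectation for compound 3 is a change of no more than the usual scatter in either direction, that is an expected step of a 1.1-fold higher number from compound 2 to compound 3 (0.05 log units; within the scatter). On that basis compound 3 is estimated to give about 200 nM in this assay, with a plausible range from 70 nM to 600 nM.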

Compound 3, half-maximal inhibitory concentration: 180 nM
Beside the measured number, compound 3's estimate is 1.1-fold (0.05 log units) above it; low and high end bracket the measured number.
By their numbers in this assay, from the lowest: compounds 1, 2 and 3 (each within the scatter of the next).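

In this assay, fluoro in place of dimethylamino on this aromatic carbon gives no change at the digits printed from compound 2 to compound 3 (within the scatter), so the two compounds cannot be told apart on this read-out. Within the data shown here, this is the first direct comparison at this position, and it shows that a group of 3 heavy atoms carrying a nitrogen and 1 hydrogen-bond acceptor, and a single fluorine with no such acceptor, can stand here with no measurable difference between them. No measurement available here bears on why the two groups read alike.

As far as these compounds go, whether a methoxy group, a carboxylic acid or a plain hydrogen on the same carbon would also read alike in this assay remains open. So does whether this exchange would read the same with a different pair of chains on the shared core.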